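A few compounds are considered here, and "the series" means these few. Any claim that something is new, unique, unknown or untested is made for them only; others in the source may bear on it.

Measured compounds in an ADME assay on L02 cells (Homo sapiens) for antiproliferative activity, read by MTT assay, with a stated time of 48 h; a higher number here means a weaker inhibitor, a lower number a stronger inhibitor:
compound 1 `CCc1ccccc1-n1nncc1CN1C(=O)C2(C(C#N)=C(N)Oc3c(N)cc4nc5ccccc5nc4c32)c2ccccc21` gives 22900 nM
compound 2 `N#CC1=C(N)Oc2c(N)cc3nc4ccccc4nc3c2C12C(=O)N(Cc1cnnn1-c1cccc(Br)c1)c1ccccc12` sits at a limit of the assay, > 50000 nM
compound 3 `N#CC1=C(N)Oc2c(N)cc3nc4ccccc4nc3c2C12C(=O)N(Cc1cnnn1-c1cc(Cl)ccc1Cl)c1ccccc12` sits at a limit of the assay, > 50000 nM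

Compound 3 therefore stands at the top of the numbers shown, with no number of its own, only a limit; compound 2 shares that position, and the limit of > 50000 nM in this assay, at which 2 of the 3 values shown sit, is where two of the three values sit. Among the measured compounds shown here, the only readable steps run from compound 1: an at least 2.1-fold higher number from compound 1 to compound 2 (0.33 log units; beyond the scatter) and an at least 2.1-fold higher number from compound 1 to compound 3 (0.33 log units; beyond the scatter), both ending at the limit. Between the two limits, a step that the two limits leave unreadable from compound 2 to compound 3.

Compound 4 `N#CC1=C(N)Oc2c(N)cc3nc4ccccc4nc3c2C12C(=O)N(Cc1cnnn1-c1ccc(Cl)cc1[N+](=O)[O-])c1ccccc12` differs from compound 3 in the group on the aromatic nitrogen: 4-chloro-2-nitrophenyl in place of 2,5-dichlorophenyl on an aromatic nitrogen. Since compound 3 already sits at the limit, and both aryl changes away from compound 1 ran to that limit, the expectation for compound 4 in this assay is a number at or beyond the limit as well, with a step that the limit leaves unreadable from compound 3 to compound 4 expected to be unreadable or within the scatter. Compound 4 is estimated at 60000 nM, within 25000 nM to 150000 nM.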

Compound 4, half-maximal inhibitory concentration: > 50000 nM
Compound 4 gave a limit, no number; the forecaster's own chance of this, stated with the estimate: 70%; the middle value does not contradict the limit.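

In this assay, 4-chloro-2-nitrophenyl on the aromatic nitrogen brings a nitro group where the earlier changes brought only halogens, yet it gives an at least 2.1-fold higher number from compound 1 to compound 4 (0.33 log units; beyond the scatter). The steps among compound 2, compound 3 and compound 4 cannot be read, as each of these compounds gives only a limit. Among the aryl groups shown, only 2-ethylphenyl in compound 1 gives a number, and a nitro-bearing aryl group now joins the two halogen-only ones at the limit: the limit of > 50000 nM in this assay, at which 3 of the 4 values shown sit.

As far as these compounds go, whether compound 2, compound 3 and compound 4 differ from one another in this assay stays open. Also open, from the compounds shown here alone, is what a longer chain in place of the ethyl group, as in 2-propylphenyl, or an amine or a carboxylic acid on the same phenyl ring would give.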